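Methoxy in place of methyl on a benzoxazole amide

This account rests on a few compounds, and the source may have more. Where it says the series, first, only, none or still open, it means among the compounds named here.

The compounds here share a core in which an amide links a chlorinated pyridine to a benzene ring that carries a fused bicyclic group. Compound 1 `COc1ccc(-c2nc3ccccc3s2)cc1NC(=O)c1cnccc1Cl` and compound 2 `Cc1ccc(-c2nc3ccccc3o2)cc1NC(=O)c1cnccc1Cl` have been measured in an ADME assay for permeability, using PAMPA; a lower number here means that the compound crosses the layer more slowly, a higher number that the compound crosses the layer faster. Compound 1 gives 121 10^-6 cm/s. Compound 2 gives 646 10^-6 cm/s, the higher of the two numbers, and the gap between them lies beyond the usual scatter; the two differ in two places at once, so the two values alone show no single change at work.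

Compound 3 `COc1ccc(-c2nc3ccccc3o2)cc1NC(=O)c1cnccc1Cl` is the next compound, and it differs from compound 2 in one place only: methoxy in place of methyl on an aromatic carbon. Within the data shown here, no measured pair shows this exact change on its own, so the expected size of the step from compound 2 to compound 3 in this assay rests on a general expectation rather than on a measured step. The step of a 1.5-fold lower number from compound 2 to compound 3 (0.19 log units; within the scatter) is expected to be a modest decrease, possibly still within the scatter. For compound 3 the estimated value in this assay is 420 10^-6 cm/s, with a likely range from 200 10^-6 cm/s to 750 10^-6 cm/s.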

Compound 3, apparent permeability: 391 10^-6 cm/s
Estimate against measurement, compound 3: 1.1-fold (0.03 log units) above, and the stated range covers the measured number.
By their numbers in this assay, from the lowest: compound 1; then compounds 3 and 2 (each within the scatter of the next).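

Compound 3 splits the double change between compound 1 and compound 2 into two single steps that can each be read in this assay on its own. At the aromatic carbon ortho to a large group, methoxy in place of methyl gives a 1.7-fold lower number from compound 2 to compound 3 (0.22 log units; within the scatter) and so stays within the scatter, which means that this change at this position has no clear effect on the read-out in this series. By contrast, 1,3-benzoxazol-2-yl in place of 1,3-benzothiazol-2-yl, with the methoxy kept, gives a 3.2-fold higher number from compound 1 to compound 3 (0.51 log units; beyond the scatter) and is the only one of the two single changes that lies beyond the scatter; no measurement shown here offers an explanation for either step.

As far as these compounds go, each change has been seen in only one setting, so it remains open whether the ring change would give a step of similar size with methyl in place of methoxy. From the compounds shown here alone, how this position would respond to an amine, a carboxylic acid or a longer chain such as ethoxy also remains open, as the methyl and methoxy compounds say nothing about those groups.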